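This account rests on a few compounds, and the source may have more. Where it says the series, first, only, none or still open, it means among the compounds named here.

Of the compounds shown here, two have so far been tested in a functional assay (Homo sapiens) for inhibition of Nucleic Acid, tested at 100 uM; a higher number here means more inhibition at the concentration tested (going by the name of the read-out), a lower number less inhibition. Compound 1 `OC[C@H]1OC(n2cnc3c(SCc4ccccc4)nccc32)[C@H](O)[C@@H]1O` gives 30% in this assay, and compound 2 `CC1OC(n2cnc3c(N)nccc32)CC1O` gives 3%. Compound 1 therefore stands highest of the two numbers; its nearest neighbour is compound 2, whose number lies lower by a gap beyond the usual scatter of repeated measurements. These two differ in more than one place, so no single change accounts for that gap. Compound 3 `OC[C@H]1OC(n2cnc3c(Cl)nccc32)[C@H](O)[C@@H]1O` has not been measured. It differs from compound 1 in one place: chloro in place of benzylsulfanyl on an aromatic carbon. Among the measured compounds shown here, no measured pair shows the effect of such a swap. For the measured compounds named here, because compound 1 at 30% is the only compound carrying benzylsulfanyl while compound 2 sits at 3%, a downward step beyond the scatter is expected. The expected step of a number 20 percentage points lower from compound 1 to compound 3 (beyond the scatter) is thus a loss. Compound 3 is estimated at 10%, within a range from 0% to 25%.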

Compound 3, a percentage reported as inhibition, at one concentration (the size of the read-out at that concentration, not a potency): 76%
The estimate for compound 3 lay 66 percentage points below the measured number; measured number outside the range, above it.
By their numbers in this assay, from the lowest: compound 2; then compound 1; then compound 3.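

In this assay, chloro in place of benzylsulfanyl on the aromatic carbon next to the ring nitrogen gives a number 46 percentage points higher from compound 1 to compound 3 (beyond the scatter). This shows that the benzylsulfanyl group is not needed for inhibition on this core, since a single chlorine atom with no ring goes with the higher number. It also shows that the number responds strongly to what this position carries, but nothing available explains the size of the step.

Going by these compounds, the swap removes the sulfur and the carbon ring together and brings in chlorine, so it remains open which of these changes carries the step. Methylsulfanyl, which keeps the sulfur without the ring, or bromo, a different halogen, at this position would help to separate them.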